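Side chain on sulfur: compound 3 to compound 4

The source may hold more compounds than are shown below. What is called first, only, known or untested is meant among the compounds shown, and "the series" means these compounds.

Measured in a functional assay on PC-3 cells (Homo sapiens) for inhibition, read by MTT assay, with a stated time of 48 h; a lower number here means a stronger inhibitor, a higher number a weaker inhibitor:
compound 1 `CCSc1nnc(-c2cc(OC)c(OC)c(OC)c2)n1-c1ccc(OC)cc1` gives 57700 nM
compound 2 `COc1ccc(-n2c(SCc3ccc(C)cc3)nnc2-c2cc(OC)c(OC)c(OC)c2)cc1` gives 56500 nM
compound 3 `COc1cc(-c2nnc(SCc3ccc(C)cc3)n2-c2ccc(N(C)C)cc2)cc(OC)c1OC` gives 37300 nM

Compound 3 at 37300 nM lies within the scatter of compound 1 and compound 2. Compound 4 `CCOC(=O)CSc1nnc(-c2cc(OC)c(OC)c(OC)c2)n1-c1ccc(N(C)C)cc1` carries ethoxycarbonyl in place of 4-methylphenyl on a saturated chain carbon bound to a sulfur. Among the compounds with values here, one measured step touches this place (a 1.0-fold lower number from compound 1 to compound 2 (0.01 log units; within the scatter)), with 4-methylphenyl in place of methyl. The other (a 1.5-fold lower number from compound 2 to compound 3 (0.18 log units; within the scatter)) lies on an aromatic carbon and bears on it less directly. Ethoxycarbonyl itself is unmeasured here, so no step beyond the scatter is expected in this assay, though the range stays wide. The estimate means a 1.2-fold higher number from compound 3 to compound 4 (0.08 log units; within the scatter) as the expected step. Compound 4 is estimated at 45000 nM (expected range 20000 nM to 90000 nM).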

Compound 4, half-maximal inhibitory concentration: > 60000 nM
Compound 4 ended at the assay's limit (the forecaster's own chance of this, stated with the estimate: 10%); at least 1.3-fold (0.12 log units) between middle value and limit.
By their numbers in this assay, from the lowest: compounds 3, 2 and 1 (each within the scatter of the next). At a limit, above all of these: compound 4.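

In this assay, within the data shown here, the only earlier change on the saturated chain carbon bound to a sulfur gave a 1.0-fold lower number from compound 1 to compound 2 (0.01 log units; within the scatter). Compound 4 gives > 60000 nM, which is a limit of the assay and not a number. Ethoxycarbonyl in place of 4-methylphenyl, a swap that removes the ring and brings in hydrogen-bond acceptors, gives an at least 1.6-fold higher number from compound 3 to compound 4 (0.20 log units; that floor lies within the scatter), so this change does not lower the number, but its full size cannot be read: the limit of > 60000 nM in this assay, at which 1 of the 4 values shown sits.

Still open, going by these compounds, is whether any group at this place gives a step beyond the scatter. A free carboxylic acid or an amide in place of ethoxycarbonyl would test this, as would a benzyl ring bearing chlorine in place of 4-methylbenzyl.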